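From 3-chloropropyl to 2-hydroxyethyl in compound 4

The source may hold more compounds than are shown below. What is called first, only, known or untested is meant among the compounds shown, and "the series" means these compounds.

In a functional assay on HepG2 cells (Homo sapiens) for antiproliferative activity, read by MTT assay, with a stated time of 72 h (a lower number here means a stronger inhibitor, a higher number a weaker inhibitor), compound 3 (`O=C1O[C@H]([C@@H](O)Cn2cc(CCCCl)nn2)C(OCc2ccccc2)=C1OCc1ccccc1`) gives 35000 nM and lies within the scatter of compound 1 (`O=C1O[C@H]([C@@H](O)Cn2cc(-c3cccc(O)c3)nn2)C(OCc2ccccc2)=C1OCc1ccccc1`) at 62700 nM as their step shows (a 1.8-fold lower number from compound 1 to compound 3 (0.25 log units; within the scatter)). Compound 2 (`CCCCCCCCCCc1cn(C[C@H](O)[C@H]2OC(=O)C(OCc3ccccc3)=C2OCc2ccccc2)nn1`) at 12200 nM has the lowest number, apart from both others (a 5.1-fold lower number from compound 1 to compound 2 (0.71 log units; beyond the scatter)) and (a 2.9-fold higher number from compound 2 to compound 3 (0.46 log units; beyond the scatter)). Compound 4 (`O=C1O[C@H]([C@@H](O)Cn2cc(CCO)nn2)C(OCc2ccccc2)=C1OCc1ccccc1`) carries hydroxy in place of chloromethyl on a saturated chain carbon, two bonds along the chain from an aromatic carbon. Only the decyl group of compound 2 has moved the number beyond the scatter, so no step beyond the scatter is expected in this assay for this shorter chain. The expected change is small (a 1.3-fold higher number from compound 3 to compound 4 (0.11 log units; within the scatter)) and slightly upward. For compound 4 the estimate is 45000 nM (range 22000 nM to 90000 nM).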

Compound 4, half-maximal inhibitory concentration: 68100 nM
The estimate for compound 4 lay 1.5-fold (0.18 log units) below the measured number; low and high end bracket the measured number.
By their numbers in this assay, from the lowest: compound 2; then compounds 3, 1 and 4 (each within the scatter of the next).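

In this assay, replacing chloromethyl with hydroxy at this place on the short chain stays within the scatter (a 1.9-fold higher number from compound 3 to compound 4 (0.29 log units; within the scatter)), so a terminal chlorine and a terminal hydroxy are not told apart here. The 2-hydroxyethyl group also stays within the scatter of the 3-hydroxyphenyl group (a 1.1-fold higher number from compound 1 to compound 4 (0.04 log units; within the scatter)), and only the decyl group stands apart (a 5.6-fold higher number from compound 2 to compound 4 (0.75 log units; beyond the scatter)). Nothing available explains these numbers. The compounds shown leave open whether an amine or a carboxylic acid at the end of this short chain would move the number beyond the scatter, and how long a chain must be before it does.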